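Replacing 3-bromophenyl with 2-methylphenyl in the series

This account rests on a few compounds, and the source may have more. Where it says the series, first, only, none or still open, it means among the compounds named here.

Compound 1 `NC(=O)c1cc(Cl)ccc1NC(=O)/C=C/c1ccccc1Br` gives 10000 nM in a functional assay on K562 cells (Homo sapiens) for inhibition, read by trypan blue exclusion, with a stated time of 48 h; a lower number here means a stronger inhibitor, a higher number a weaker inhibitor. Compound 2 `NC(=O)c1cc(Cl)ccc1NC(=O)/C=C/c1cccc(Br)c1` gives > 10000 nM in this assay, which is a limit of the assay and not a number. Going by the values given here, the only measured step, a number no lower from compound 1 to compound 2 (the limit leaves the size open), has no readable size. Compound 3 `Cc1ccccc1/C=C/C(=O)Nc1ccc(Cl)cc1C(N)=O` differs from compound 2 by 2-methylphenyl in place of 3-bromophenyl on a double-bonded chain carbon bound to a double-bonded chain carbon. The expectation rests on compound 1, the nearest measured compound, which carries 2-bromophenyl where compound 3 carries 2-methylphenyl. A small move towards a lower number, possibly within the scatter, is expected in this assay, with the estimate being a number no higher from compound 2 to compound 3 (the limit leaves the size open). Compound 3 is estimated at 10000 nM, with an expected range of 4000 nM to 25000 nM.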

Compound 3, half-maximal inhibitory concentration: 9500 nM
The estimate for compound 3 lay 1.1-fold (0.02 log units) above the measured number, and the stated range covers the measured number.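

Methyl in place of bromo on an aromatic carbon gives the first readable step in the series in this assay, a 1.1-fold lower number from compound 1 to compound 3 (0.02 log units; within the scatter), so 2-methylphenyl and 2-bromophenyl are not told apart here. The exchange of 3-bromophenyl for 2-methylphenyl gives an at least 1.0-fold lower number from compound 2 to compound 3 (0.02 log units; that floor lies within the scatter), and only this floor can be read. Compound 2 carries a limit of the assay, not a number, and that is why the size stays open: the limit of > 10000 nM in this assay, at which 1 of the 3 values shown sits.

On these data alone, whether an amine or a carboxylic acid on that aromatic carbon would move the number beyond the scatter remains open. As far as these compounds go, the step between the 2-bromophenyl and 3-bromophenyl compounds cannot be read, so the effect of that shift also stays open.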